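A few compounds are considered here, and "the series" means these few. Any claim that something is new, unique, unknown or untested is made for them only; others in the source may bear on it.

Measured in a functional assay on HeLa cells (Homo sapiens) for cytotoxicity, read by MTT assay; a higher number here means a weaker inhibitor, a lower number a stronger inhibitor:

- Compound 1 `CC(C)=CC[C@@H](OC(=O)c1ccco1)C1=CC(=O)c2c(O)ccc(O)c2C1=O`: 80300 nM
- Compound 2 `CC[C@](C)(O)CC(=O)O[C@H](CC=C(C)C)C1=CC(=O)c2c(O)ccc(O)c2C1=O`: 30200 nM
- Compound 3 `CCC(CO[C@H](CC=C(C)C)C1=CC(=O)c2c(O)ccc(O)c2C1=O)OC(C)=O`: 44000 nM

In this assay, compound 3, at 44000 nM, lies within the scatter of both other compounds, so it cannot be separated from either of them. Compound 4 `CC(C)=CC[C@@H](OC(=O)C1CCCO1)C1=CC(=O)c2c(O)ccc(O)c2C1=O` is the next to be considered. It places (oxolan-2-yl)carbonyl in place of 2-acetoxybutyl on an oxygen on a saturated carbon.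

Among the compounds with values here, no measured step leads directly to compound 4, but three exchanges at this same oxygen bear on it. Two are small, with a 1.8-fold lower number from compound 1 to compound 3 (0.26 log units; within the scatter) and a 1.5-fold higher number from compound 2 to compound 3 (0.16 log units; within the scatter). The third, a 2.7-fold lower number from compound 1 to compound 2 (0.42 log units; beyond the scatter), is the only one beyond the scatter, and it is modest. All three compounds therefore span a narrow range, and no step beyond the scatter is expected in this assay. The expected change is a 1.0-fold higher number from compound 3 to compound 4 (0.01 log units; within the scatter). For compound 4 the estimated value is 45000 nM, with an expected range of 20000 nM to 95000 nM.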

Compound 4, half-maximal inhibitory concentration: 17000 nM
For compound 4 the middle estimate is 2.6-fold (0.42 log units) above the measured one; the whole stated range lies above it.
By their numbers in this assay, from the lowest: compounds 4, 2, 3 and 1 (each within the scatter of the next, the first and the last beyond it).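

In this assay, the exchange of ring on the carbonyl carbon proves to matter: oxolan-2-yl in place of furan-2-yl gives a 4.7-fold lower number from compound 1 to compound 4 (0.67 log units; beyond the scatter) and so reaches beyond the scatter. Within the data shown here, the same oxygen on a saturated carbon also separates (oxolan-2-yl)carbonyl from 2-acetoxybutyl, with a 2.6-fold lower number from compound 3 to compound 4 (0.41 log units; beyond the scatter) as the result, although the earlier compounds had given only one step beyond the scatter at this place. Oxolan-2-yl in place of 2-hydroxy-2-methylbutyl, by contrast, gives a 1.8-fold lower number from compound 2 to compound 4 (0.25 log units; within the scatter) and cannot be told apart from it here, so a ring on the carbonyl carbon is not required for this level of activity.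

From the compounds shown here alone, whether a pyrrolidine ring, an amine or a longer chain on that carbonyl carbon would keep or extend this step remains open. Nothing available gives a reason for any of these differences.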